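A Methoxy Swap on the Chloroaryl Ring of Compound 2

The source may report more compounds than this note shows. Statements on the series, on what has been measured and on what is new or still open speak of the compounds shown alone.

Compound 1 `Clc1ccc(C2=NN(c3ccc(-c4ccccc4)nn3)C(c3ccc(Cl)cc3)C2)cc1`
Compound 2 `FC(F)(F)c1ccc(C2CC(c3ccc(Cl)cc3)=NN2c2ccc(-c3ccccc3)nn2)cc1`
Compound 3 `COc1ccc(C2CC(c3ccc(Cl)cc3)=NN2c2ccc(-c3ccccc3)nn2)cc1`
Compound 4 `COc1ccc(C2=NN(c3ccc(-c4ccccc4)nn3)C(c3ccc(C(F)(F)F)cc3)C2)cc1`, not yet measured

Within the data shown here, in a functional assay on Caco-2 cells (Homo sapiens) for antiproliferative activity, read by MTT assay, with a stated time of 24 h (a lower number here means a stronger inhibitor, a higher number a weaker inhibitor), compound 2 gives 10000 nM, the only plain number among the three. Compound 1 reaches only the assay limit, > 100000 nM. Compound 3 likewise reaches only the limit, > 100000 nM; two of the three values sit there (the limit of > 100000 nM in this assay, at which 2 of the 3 values shown sit). Compound 2 differs from compound 1 by an at least 10-fold lower number from compound 1 to compound 2 (1.00 log units; beyond the scatter) and from compound 3 by an at least 10-fold higher number from compound 2 to compound 3 (1.00 log units; beyond the scatter). Compound 4 changes compound 2 elsewhere: methoxy in place of chloro on an aromatic carbon. The comparable swap on the other ring, a step that the two limits leave unreadable from compound 1 to compound 3, shows nothing readable. Methoxy has so far only appeared with a limit, so compound 4 is expected to give a higher number, roughly a 3.0-fold higher number from compound 2 to compound 4 (0.48 log units; beyond the scatter), an estimate of 30000 nM with a range from 8000 nM to 100000 nM.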

Compound 4, half-maximal inhibitory concentration: 65000 nM
Beside the measured number, compound 4's estimate is 2.2-fold (0.34 log units) below it; measured number inside the range.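

In this assay, the change from 4-chlorophenyl to 4-methoxyphenyl now has a readable size: a 6.5-fold higher number from compound 2 to compound 4 (0.81 log units; beyond the scatter). Compound 4 keeps a plain number with methoxy on board, so in this series methoxy does not always come with a limit. The earlier methoxy in place of chloro step, on the other ring, cannot be read, since both of its values are limits: the limit of > 100000 nM in this assay, at which 2 of the 4 values shown sit.

From the compounds shown here alone, what an amine or a carboxylic acid on this aromatic carbon would give remains open. Also open, going by these compounds, is whether any group there would give a lower number than compound 2.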